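Cytotoxicity notes: dimethylamino in place of phenoxy

A few compounds are considered here, and "the series" means these few. Any claim that something is new, unique, unknown or untested is made for them only; others in the source may bear on it.

Measured compounds:
compound 1 `COc1cc(C)cc(-c2c(-c3ccnc(-c4ccc(C(C)=O)cc4)c3)cnn2CC#N)c1` — 91%
compound 2 `Cc1cc(O)cc(-c2nn(CC#N)cc2-c2ccnc(-c3ccc(Oc4ccccc4)cc3)c2)c1` — 95%

In a functional assay on MDA-MB-435 cells (Homo sapiens) for cytotoxicity, read by sulforhodamine B assay, with a stated time of 48 h, tested at 0.01 uM (on this read-out higher numbers stand for a weaker effect at the one concentration tested and lower numbers for a stronger effect), compound 1 gives 91% and compound 2 gives 95%. The two numbers lie within the scatter of each other, so neither compound stands apart from the other in this assay; both show little effect at the single concentration tested.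

Compound 3 `Cc1cc(O)cc(-c2nn(CC#N)cc2-c2ccnc(-c3ccc(N(C)C)cc3)c2)c1` is not yet measured. It differs from compound 2 in one place: dimethylamino in place of phenoxy on an aromatic carbon. Among the compounds with values here, no pair of measured compounds differing in one place is available, so the series itself gives no calibration for the size of such a change in this assay.

With both measured compounds sitting close together and near full activity, compound 3 is expected to behave much like compound 2, and the step of a number 5 percentage points lower from compound 2 to compound 3 (within the scatter) is estimated to fall within the scatter rather than beyond it. Compound 3 is accordingly estimated at 90% in this assay, with a range from 72% to 102%.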

Compound 3, a percentage reported as activity, at one concentration (the size of the read-out at that concentration, not a potency): 91%
Compound 3: middle estimate off by 1 percentage points, on the low side; measured number inside the range.
By their numbers in this assay, from the lowest: compounds 1, 3 and 2 (each within the scatter of the next).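

Within the data shown here, this is the first one-place step. In this assay the exchange of phenoxy for dimethylamino on an aromatic carbon para to a large group gives a number 4 percentage points lower from compound 2 to compound 3 (within the scatter) and thus separates neither compound from the other, so at the single concentration tested, a group of 7 heavy atoms with a ring and one of 3 heavy atoms without a ring cannot be told apart on this carbon. No measurement at hand bears on this result.

From the compounds shown here alone, whether a carboxylic acid or a primary amine on the same carbon would give a step beyond the scatter remains open. Also open is whether phenoxy and dimethylamino would separate at a concentration other than the one shown.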